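The source may report more compounds than this note shows. Statements on the series, on what has been measured and on what is new or still open speak of the compounds shown alone.

Compound 1 `CCOC(=O)c1c(C)cc2cnn(-c3ccc(F)cc3)c(=O)c2c1C`, compound 2 `CCOC(=O)c1c(C)cc2cnn(-c3ccc(C)c(Cl)c3)c(=O)c2c1C` and compound 3 `CCOC(=O)c1c(C)cc2cnn(-c3ccc(C(=O)O)cc3)c(=O)c2c1C` share one core and differ only in the aryl group on the aromatic nitrogen. In a functional assay (plasma) for inhibition, with Oryctolagus cuniculus as the target (a higher number here means that more compound is needed for the effect, a lower number that less compound is needed), compound 1 gives only a limit of the assay, >= 50 uM. Compound 2 likewise reaches only a limit in this assay, >= 50 uM. Compound 3 too stops at a limit in this assay, >= 50 uM. Compound 3 thus stands exactly where the other two stand, at the limit of >= 50 uM in this assay, at which 3 of the 3 values shown sit, so nothing separates it from them on the numbers. The steps a step that the two limits leave unreadable from compound 1 to compound 2, a step that the two limits leave unreadable from compound 1 to compound 3 and a step that the two limits leave unreadable from compound 2 to compound 3 are all left unreadable by these limits, and none gives a size or a direction.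

Compound 4 `CCOC(=O)c1c(C)cc2cnn(-c3ccc([N+](=O)[O-])cc3)c(=O)c2c1C` differs from compound 3 by nitro in place of carboxy on an aromatic carbon. The measured steps that bear on this change are the three unreadable ones, so no size can be drawn from them. Compound 4 is therefore expected to remain at or near the limit in this assay, with no step beyond the scatter being predictable. The expected step is a step that the limit leaves unreadable from compound 3 to compound 4. Compound 4 is estimated at 60 uM, within a range from 20 uM to 200 uM.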

Compound 4, concentration for half-maximal effect: >= 50 uM
Compound 4 was reported as a limit; the forecaster's own chance of this, stated with the estimate: 80%; the middle value does not contradict the limit.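

Compound 4, like compound 1, compound 2 and compound 3, stops at a limit in this assay, so its steps to those three cannot be read: the limit of >= 50 uM in this assay, at which 4 of the 4 values shown sit.

The compounds shown leave open whether the four aryl groups on the aromatic nitrogen differ at all in this assay.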